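The compounds below may be only part of what the source reports. "The series", "measured", "known", "first", "only" and "open" are said of these compounds alone.

Measured in a functional assay on HL-60 cells (Homo sapiens) for cytotoxicity, read by WST assay, with a stated time of 48 h; a higher number here means a weaker inhibitor, a lower number a stronger inhibitor:
- Compound 1 `COc1cc(C(c2ccc(O)c(OC)c2)[C@@H](C)C(C)C)ccc1O`: 20000 nM
- Compound 2 `CCCCC[C@H](C(C)C)C(c1ccc(O)c(OC)c1)c1ccc(O)c(OC)c1`: 9600 nM

Within the data shown here, compound 2 has the lower number of the pair, 9600 nM, which makes it the stronger inhibitor of the two so far. Among the measured compounds shown here, its only neighbour is compound 1, at 20000 nM.

Compound 3 `COc1cc(C(c2ccc(O)c(OC)c2)[C@H](C)[C@@H](C)CF)ccc1O` has not yet been measured. It differs from compound 2 in one place: 2-(fluoromethyl)-1-methylpropyl in place of 1-isopropylhexyl on a saturated chain carbon bound to two aromatic carbons.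

For the measured compounds named here, only one measured step bears on this change: a 2.1-fold lower number from compound 1 to compound 2 (0.32 log units; beyond the scatter). That step brought in the 1-isopropylhexyl group on the same saturated chain carbon bound to two aromatic carbons, and it was modest. Compound 3 gives that group up again, so a move back to a higher number in this assay, of similar modest size, is expected. Going by the values given here, no measured compound carries the 2-(fluoromethyl)-1-methylpropyl group, so this expectation is uncertain and the range is kept wide.

The expected step is a 2.1-fold higher number from compound 2 to compound 3 (0.32 log units; beyond the scatter). For compound 3 the estimated value is 20000 nM, with an expected range of 9000 nM to 45000 nM.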

Compound 3, half-maximal inhibitory concentration: 45000 nM
The estimate for compound 3 lay 2.3-fold (0.35 log units) below the measured number, and the stated range covers the measured number.
By their numbers in this assay, from the lowest: compound 2; then compound 1; then compound 3.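

In this assay, replacing the 1-isopropylhexyl group with 2-(fluoromethyl)-1-methylpropyl on the saturated chain carbon bound to two aromatic carbons gives a 4.7-fold higher number from compound 2 to compound 3 (0.67 log units; beyond the scatter), so giving up the longer group costs more here than the earlier comparison alone suggested. Losing the 1-isopropylhexyl group does not simply return the number to that of compound 1, since the new group gives a 2.3-fold higher number from compound 1 to compound 3 (0.35 log units; beyond the scatter) and leaves compound 3 as the weakest inhibitor of the three. This position therefore responds to more than the removal of the longer group, and the two smaller groups are not interchangeable in this assay, although no measurement here explains the difference between them.

The compounds shown leave open whether the higher number of compound 3 follows from its fluorine atom or from another difference between its group and the 1,2-dimethylpropyl group of compound 1. They also leave open how a hydroxymethyl group, a trifluoromethyl group or a longer chain ending in fluorine would read on the same carbon.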